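A few compounds are considered here, and "the series" means these few. Any claim that something is new, unique, unknown or untested is made for them only; others in the source may bear on it.

Measured in a functional assay on the whole organism (strain Sprague-Dawley) for inhibition, with Rattus norvegicus as the target, read by paw edema, with stated times of 30 min and 2 h, at a dose of 80 mg/kg by the oral route; a higher number here means more inhibition at the dose given (going by the name of the read-out), a lower number less inhibition:
compound 1 `O=c1c2ccccc2nc(CO[N+](=O)[O-])n1NS(=O)(=O)c1ccccc1` — 11.6%
compound 2 `Cc1nc2ccccc2c(=O)n1NS(=O)(=O)c1ccccc1` — 22.2%
compound 3 `Cc1ccc(S(=O)(=O)Nn2c(C)nc3ccccc3c2=O)cc1` — 24.2%

Compound 3 is separated from compound 1 by a gap beyond the scatter; against compound 2 the two values lie within the scatter of each other, so no order between them can be read. Compound 4 `Cc1ccc(S(=O)(=O)Nn2c(CO[N+](=O)[O-])nc3ccccc3c2=O)cc1` differs from compound 3 by nitrooxy in place of hydrogen on a saturated chain carbon bound to an aromatic carbon. Among the measured compounds shown here, the one measured step that bears on this change is a number 10.6 percentage points higher from compound 1 to compound 2 (beyond the scatter), the same alteration run in the opposite direction. The other step, a number 2 percentage points higher from compound 2 to compound 3 (within the scatter), concerns a different position and stays within the scatter. In this assay compound 4 is therefore expected to lose about as much as compound 2 gained, a number 10.2 percentage points lower from compound 3 to compound 4 (beyond the scatter). The estimate for compound 4 is 14%, with a range of 5% to 24%.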

Compound 4, a percentage reported as inhibition, in the whole organism at one dose (the size of the read-out at that dose, not a potency): 15.7%
Beside the measured number, compound 4's estimate is 1.7 percentage points below it, within the range that was stated.
By their numbers in this assay, from the lowest: compounds 1, 4, 2 and 3 (each within the scatter of the next, the first and the last beyond it).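

In this assay nitrooxy in place of hydrogen on a saturated chain carbon bound to an aromatic carbon now reads on a second core (a number 8.5 percentage points lower from compound 3 to compound 4 (within the scatter)), and this step, unlike its counterpart, does not clear the scatter. The two readings still agree in size: the same change on two cores in this assay, a number 10.6 percentage points higher (beyond the scatter) from compound 1 to compound 2 and a number 8.5 percentage points higher (within the scatter) from compound 4 to compound 3, 2.1 percentage points apart, within the scatter of two such steps.
Methyl in place of hydrogen on an aromatic carbon also reads a second time (a number 4.1 percentage points higher from compound 1 to compound 4 (within the scatter)), again too small to separate the compounds: the same change on two cores in this assay, a number 2 percentage points higher (within the scatter) from compound 2 to compound 3 and a number 4.1 percentage points higher (within the scatter) from compound 1 to compound 4, 2.1 percentage points apart, within the scatter of two such steps.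

Open, going by these compounds, is whether another group on that chain carbon, such as a hydroxyl or an amine, would read like nitrooxy or like hydrogen.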